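Series notes: methyl in place of fluoro

A few compounds are considered here, and "the series" means these few. Any claim that something is new, unique, unknown or untested is made for them only; others in the source may bear on it.

Values in a functional assay on MIA PaCa-2 cells (Homo sapiens) for inhibition, read by MTT assay (on this read-out higher numbers stand for weaker inhibition and lower numbers for stronger inhibition), for the measured compounds
- compound 1 `O=C(Nc1ccc[n+]([O-])c1)c1cc2cnc(Nc3ccc(N4CCNCC4)cn3)nc2n1C1CCCC1` gives 125000 nM
- compound 2 `COc1cccc(NC(=O)c2cc3cnc(Nc4ccc(N5CCNCC5)cn4)nc3n2C2CCCC2)c1` gives 2650 nM
- compound 3 `O=C(Nc1ccccc1F)c1cc2cnc(Nc3ccc(N4CCNCC4)cn3)nc2n1C1CCCC1` gives 3670 nM

Compound 3 lies within the scatter of compound 2 (a 1.4-fold higher number from compound 2 to compound 3 (0.14 log units; within the scatter)) and far from compound 1 (a 34-fold lower number from compound 1 to compound 3 (1.53 log units; beyond the scatter)). Compound 4 `Cc1ccccc1NC(=O)c1cc2cnc(Nc3ccc(N4CCNCC4)cn3)nc2n1C1CCCC1` carries methyl in place of fluoro on an aromatic carbon, ortho to a large group (methyl in place of fluoro on an aromatic carbon). The closest measured change swaps 3-methoxyphenyl for 2-fluorophenyl, and it stays within the scatter. Within the data shown here, the large steps, such as the one from compound 1 (a 47-fold lower number from compound 1 to compound 2 (1.67 log units; beyond the scatter)), remove a ring with a hetero atom, which does not happen here. No step beyond the scatter is therefore expected in this assay and the estimated step is small (a 1.1-fold lower number from compound 3 to compound 4 (0.06 log units; within the scatter)). Compound 4 is estimated at 3200 nM (1500 nM to 7000 nM).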

Compound 4, half-maximal inhibitory concentration: 2500 nM
Beside the measured number, compound 4's estimate is 1.3-fold (0.11 log units) above it; low and high end bracket the measured number.
By their numbers in this assay, from the lowest: compounds 4, 2 and 3 (each within the scatter of the next); then compound 1.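

In this assay methyl and fluoro on this aromatic carbon, ortho to a large group, cannot be told apart (a 1.5-fold lower number from compound 3 to compound 4 (0.17 log units; within the scatter)). The 2-methylphenyl amide also sits level with the 3-methoxyphenyl amide (a 1.1-fold lower number from compound 2 to compound 4 (0.03 log units; within the scatter)), while the gap to the ring with a hetero atom in compound 1 stays large (a 50-fold lower number from compound 1 to compound 4 (1.70 log units; beyond the scatter)). No measured data explain why this swap leaves the number within the scatter.

As far as these compounds go, whether an amine, a carboxylic acid or a longer chain on this aromatic carbon would keep the number in this range stays open. So does whether methyl in place of fluoro reads the same on the other carbons of this ring.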